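Swapping an Ester Arm for a Hydroxyl Arm

The source may report more compounds than this note shows. Statements on the series, on what has been measured and on what is new or still open speak of the compounds shown alone.

Of the compounds shown here, two sharing one core have been measured in an assay on cells for agonist activity at vitamin D3 receptor (Homo sapiens), with a stated time of 96 h; on this read-out higher numbers stand for an effect only at larger amounts of compound and lower numbers for an effect already at smaller amounts. Compound 1, `CCN(CC)CCNC(=O)c1ccc(C(CC)(CC)c2ccc(OCCC(O)(CC)CC)c(C)c2)n1CC`, carries a basic amine-bearing chain on its amide and gives 2.3 nM. Among the measured compounds shown here, compound 2, `CCOC(=O)CN(C)C(=O)c1ccc(C(CC)(CC)c2ccc(OCCC(O)(CC)CC)c(C)c2)n1CC`, carries instead a methyl group and an ester-bearing chain on the same amide and gives 520 nM, the highest number of the two; the only measured step is a 230-fold higher number from compound 1 to compound 2 (2.35 log units; beyond the scatter).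

Compound 3, `CCn1c(C(=O)N(C)CCO)ccc1C(CC)(CC)c1ccc(OCCC(O)(CC)CC)c(C)c1`, differs from compound 2 by hydroxymethyl in place of ethoxycarbonyl on a saturated chain carbon bound to an amide-type nitrogen. The measured step from compound 1 to compound 2 changes a different part of the amide substituent, so it offers no direct guide to this change; it only shows that the amide substituent is a place where this assay responds strongly. For the measured compounds named here, with no step that directly matches the change, the expected step in this assay is a 2.6-fold lower number from compound 2 to compound 3 (0.41 log units; beyond the scatter), estimated as a modest move toward lower numbers, with real uncertainty in either direction. Compound 3 is therefore expected to give about 200 nM, in a range from 40 nM to 800 nM.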

Compound 3, half-maximal effective concentration: 52.7 nM
Compound 3: middle estimate off by 3.8-fold (0.58 log units), on the high side; low and high end bracket the measured number.
By their numbers in this assay, from the lowest: compound 1; then compound 3; then compound 2.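

In this assay, hydroxymethyl in place of ethoxycarbonyl on a saturated chain carbon bound to an amide-type nitrogen gives a 9.9-fold lower number from compound 2 to compound 3 (0.99 log units; beyond the scatter), which shows that the far end of this amide substituent matters on its own, even with the methyl on the amide nitrogen kept the same. The hydroxyl-bearing arm closes only part of the gap, as (2-hydroxyethyl)(methyl)amino in place of (2-(diethylamino)ethyl)amino on a carbonyl carbon still leaves a 23-fold higher number from compound 1 to compound 3 (1.36 log units; beyond the scatter). Nothing in the available data accounts for either step, so both stand as observations only.

The remaining gap to compound 1 involves two differences at once, the end of the chain and the methyl in place of the amide hydrogen, and the compounds shown do not separate them; a (2-(diethylamino)ethyl)(methyl)amino group or a (2-hydroxyethyl)amino group on the same carbonyl would do so. From the compounds shown here alone, it also remains open how a carboxylic acid at the end of this arm, or a longer chain carrying the hydroxyl, would read out in this assay.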